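Adding Dimethylamino to a Small, Flat Series

The source may hold more compounds than are shown below. What is called first, only, known or untested is meant among the compounds shown, and "the series" means these compounds.

In a functional assay on the whole organism for inhibition, with Rattus norvegicus as the target (on this read-out lower numbers stand for stronger inhibition and higher numbers for weaker inhibition), compound 1 `O=C1ON=C(c2cccs2)/C1=C/c1ccccc1O` gives 5700 nM, compound 2 `O=C1ON=C(c2cccs2)/C1=C/c1ccccc1` gives 4400 nM and compound 3 `O=C1ON=C(c2cccs2)/C1=C/c1cccs1` gives 3700 nM. Compound 2 thus lies within the usual scatter of both of the other compounds, so these three numbers cannot be ranked with any confidence.

The next structure is compound 4 `CN(C)c1ccc(/C=C2\C(=O)ON=C2c2cccs2)cc1`, which has not yet been measured. It differs from compound 2 by dimethylamino in place of hydrogen on an aromatic carbon, para to a large group: dimethylamino in place of hydrogen on an aromatic carbon.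

For the measured compounds named here, two measured steps bear on this change. The closer one also alters a group on an aromatic carbon, with hydrogen in place of hydroxy: a 1.3-fold lower number from compound 1 to compound 2 (0.11 log units; within the scatter). The other exchanges phenyl for thiophen-2-yl: a 1.2-fold lower number from compound 2 to compound 3 (0.08 log units; within the scatter). Both steps stay within the scatter, which gives no sign that this series responds strongly to such edits. Going by the values given here, still, no measured compound carries dimethylamino, so the evidence is indirect and the range must stay wide.

No change beyond the scatter is expected in this assay. The estimated step is a 1.0-fold higher number from compound 2 to compound 4 (0.01 log units; within the scatter). For compound 4, the estimated value is 4500 nM, with an expected range from 1500 nM to 13000 nM.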

Compound 4, half-maximal inhibitory concentration: 4200 nM
Beside the measured number, compound 4's estimate is 1.1-fold (0.03 log units) above it; the range from low to high includes it.
By their numbers in this assay, from the lowest: compounds 3, 4, 2 and 1 (each within the scatter of the next).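

Placing dimethylamino on an aromatic carbon of the six-membered ring, para to a large group, gives a 1.0-fold lower number from compound 2 to compound 4 (0.02 log units; within the scatter) in this assay. The earlier steps shown here exchanged only hydroxy for hydrogen and phenyl for thiophen-2-yl, whereas compound 4 shows that this position can carry a group of 3 heavy atoms, 2 carbon and 1 nitrogen, with no change that can be told apart from the scatter of repeated measurements. Nothing in the information available explains why the number stays flat.

Going by these compounds, whether a carboxylic acid or a longer amine chain on this same carbon would move the number beyond the scatter remains open, as does the effect of dimethylamino on another carbon of the ring. Also unresolved is what happens when a methyl group or a phenyl ring replaces the thiophen-2-yl that all four compounds share on the core, a part of the structure that has stayed fixed throughout this small series.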